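Swapping trifluoromethyl for chloro on compound 3

The compounds below may be only part of what the source reports. "The series", "measured", "known", "first", "only" and "open" are said of these compounds alone.

Measured in a functional assay on HL-60 cells (Homo sapiens) for cytotoxicity, read by WST assay, with a stated time of 48 h; a lower number here means that less compound is needed, a higher number that more compound is needed for the effect:
- Compound 1 `O=C1OC[C@H](Cc2ccccc2)[C@H]1Cc1ccccc1Cl` gives 37000 nM
- Compound 2 `COCOc1cccc(C[C@H]2C(=O)OC[C@@H]2Cc2ccccc2)c1` gives 80000 nM
- Compound 3 `O=C1OC[C@H](Cc2ccccc2)[C@H]1Cc1cccc(C(F)(F)F)c1` gives 34000 nM

Compound 3 and compound 1 lie within the scatter of each other, and compound 2 gives a higher number than either. The next structure, compound 4 `O=C1OC[C@H](Cc2ccccc2)[C@H]1Cc1cccc(Cl)c1`, has chloro in place of trifluoromethyl on an aromatic carbon. Among the compounds with values here, only one measured step bears on this: a 2.4-fold lower number from compound 2 to compound 3 (0.37 log units; beyond the scatter), a modest shift from swapping a different group on an aromatic carbon. Compound 1 also carries chloro and gives 37000 nM, close to compound 3 . On this limited evidence, the expected change is a 1.0-fold higher number from compound 3 to compound 4 (0.01 log units; within the scatter), with no shift beyond the scatter in either direction. Compound 4 is estimated at 35000 nM, with an expected range from 17000 nM to 70000 nM.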

Compound 4, half-maximal effective concentration: 36000 nM
Compound 4: middle estimate off by 1.0-fold (0.01 log units), on the low side; low and high end bracket the measured number.
By their numbers in this assay, from the lowest: compounds 3, 4 and 1 (each within the scatter of the next); then compound 2.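

In this assay, swapping trifluoromethyl for chloro on this aromatic carbon makes no difference beyond the scatter, giving a 1.1-fold higher number from compound 3 to compound 4 (0.02 log units; within the scatter). Methoxymethoxy now stands apart from two other groups at this place, since chloro also gives a 2.2-fold lower number from compound 2 to compound 4 (0.35 log units; beyond the scatter). Exchanging 2-chlorophenyl for 3-chlorophenyl also leaves the reading within the scatter, with a 1.0-fold lower number from compound 1 to compound 4 (0.01 log units; within the scatter). Nothing available explains these results. Going by these compounds, whether an amine or a carboxylic acid at this place would move the number beyond the scatter remains open.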